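Trifluoromethyl to Methoxy: Expected Effect on Cytotoxicity

A few compounds are considered here, and "the series" means these few. Any claim that something is new, unique, unknown or untested is made for them only; others in the source may bear on it.

Among the measured compounds shown here, compound 3 `COc1cc2c(Oc3ccc(NC(=O)c4cc(-c5ccc(C(F)(F)F)cc5)ccn4)cc3F)ccnc2cc1OCCCN1CCN(C)CC1` stands, in a functional assay on NCI-H460 cells (Homo sapiens) for cytotoxicity, read by MTT assay, with a stated time of 72 h (on this read-out lower numbers stand for stronger inhibition and higher numbers for weaker inhibition), at 160 nM, the second highest of the three numbers measured so far. Its nearest neighbour is compound 2 `COc1cc2c(Oc3ccc(NC(=O)c4cc(-c5ccccc5F)ccn4)cc3F)ccnc2cc1OCCCN1CCN(C)CC1`, which gives 140 nM; the step of a 1.1-fold higher number from compound 2 to compound 3 (0.06 log units; within the scatter) lies within the scatter. Furthest away is compound 1 `COc1ccc(-c2ccnc(C(=O)Nc3ccc(Oc4ccnc5cc(OCCCN6CCCCC6)c(OC)cc45)c(F)c3)c2)cc1`, which gives 200 nM, yet that gap too is within the scatter, so the three compounds cannot be told apart on this read-out.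

Compound 4 `COc1ccc(-c2ccnc(C(=O)Nc3ccc(Oc4ccnc5cc(OCCCN6CCN(C)CC6)c(OC)cc45)c(F)c3)c2)cc1` differs from compound 3 by a single change: methoxy in place of trifluoromethyl on an aromatic carbon. For the measured compounds named here, only one measured step bears on a change of this kind, namely a 1.1-fold higher number from compound 2 to compound 3 (0.06 log units; within the scatter), and it is within the scatter. Compound 1 carries the same methoxy group that enters in compound 4, but the two compounds also differ elsewhere in their structures, so the value of compound 1 can only be set beside that of compound 3, and the two sit within the scatter of each other. Going by the values given here, no measured step therefore points to a change beyond the scatter. Accordingly, compound 4 is expected to lie close, the step being estimated as a 1.1-fold higher number from compound 3 to compound 4 (0.03 log units; within the scatter). For compound 4 the estimate in this assay is 170 nM, with a range from 80 nM to 360 nM.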

Compound 4, half-maximal inhibitory concentration: 370 nM
For compound 4 the middle estimate is 2.2-fold (0.34 log units) below the measured one, and the stated range ends below it.
By their numbers in this assay, from the lowest: compounds 2, 3, 1 and 4 (each within the scatter of the next, the first and the last beyond it).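

Among the compounds shown here, the trifluoromethyl-to-methoxy change is the first to move the number beyond the scatter: in this assay the exchange gives a 2.3-fold higher number from compound 3 to compound 4 (0.36 log units; beyond the scatter). The 4-methoxyphenyl group also separates from 2-fluorophenyl, with a 2.6-fold higher number from compound 2 to compound 4 (0.42 log units; beyond the scatter), so the aryl group at this place is not as indifferent as the earlier trifluoromethyl and fluoro pair suggested, although both of these steps remain modest. The chain end offers no such separation, since 4-methylpiperazin-1-yl in place of piperidin-1-yl gives a 1.9-fold higher number from compound 1 to compound 4 (0.27 log units; within the scatter), and nothing given here accounts for the effect of the methoxy group.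

Going by these compounds, it remains open whether a nitrile, a chlorine atom or a dimethylamino group on the same aromatic carbon would track with trifluoromethyl or with methoxy, and so whether methoxy is a special case or part of a wider trend. It is also open whether the trifluoromethyl-to-methoxy step keeps its size with piperidin-1-yl at the end of the chain, since the step shown here rests on a single pair carrying 4-methylpiperazin-1-yl.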